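The source may hold more compounds than are shown below. What is called first, only, known or untested is meant among the compounds shown, and "the series" means these compounds.

Compound 1 `O=C(Nc1ccc(Cl)cc1)Nc1ccc(Nc2ncnc3c2OCCN3)cc1`: in an assay on isolated protein for inhibition of proto-oncogene tyrosine-protein kinase receptor Ret variant V804L (Homo sapiens), read by 33P incorporation, with stated times of 15 min and 40 min (a lower number here means a stronger inhibitor, a higher number a weaker inhibitor), compound 1 gives > 10000 nM, which is a limit of the assay rather than a number.
Compound 2 `COc1ccc(NC(=O)Nc2ccc(Nc3ncnc4c3OCCN4)cc2)cc1`: in this assay compound 2 gives 1220 nM.
Compound 3 `O=C(Nc1ccc(Nc2ncnc3c2OCCN3)cc1)Nc1cc(Cl)cc(Cl)c1`: in this assay compound 3 gives 4480 nM.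

Among the two numbers shown, compound 3 has the higher one; its nearest neighbour is compound 2, with a 3.7-fold higher number from compound 2 to compound 3 (0.56 log units; beyond the scatter). Compound 1 sits at the limit of > 10000 nM in this assay, at which 1 of the 3 values shown sits, so its step to compound 3 can only be bounded, an at least 2.2-fold lower number from compound 1 to compound 3 (0.34 log units; beyond the scatter), and the step from compound 1 to compound 2 is likewise a bound, an at least 8.1-fold lower number from compound 1 to compound 2 (0.91 log units; beyond the scatter).

Compound 4 `O=C(Nc1ccc(Nc2ncnc3c2OCCN3)cc1)Nc1cccs1` differs from compound 3 in one place: thiophen-2-yl in place of 3,5-dichlorophenyl on an amide-type nitrogen. Both measured steps that change the group on the amide-type nitrogen bear on this: a swap of substituents on the ring shifted the number by a 3.7-fold higher number from compound 2 to compound 3 (0.56 log units; beyond the scatter), and a change in the substitution pattern gave an at least 2.2-fold lower number from compound 1 to compound 3 (0.34 log units; beyond the scatter). Neither step replaces the six-membered ring with a five-membered one, so the direction is uncertain, but steps of this kind here were modest. Compound 4 is therefore expected to show a 1.5-fold lower number from compound 3 to compound 4 (0.17 log units; within the scatter) in this assay. The estimate for compound 4 is 3000 nM, expected to fall between 800 nM and 12000 nM.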

Compound 4, half-maximal inhibitory concentration: > 10000 nM
Compound 4: a limit, no number; the forecaster's own chance of this, stated with the estimate: 15%; at least 3.3-fold (0.52 log units) between middle value and limit.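

In this assay, thiophen-2-yl on the amide-type nitrogen is the first change shown that replaces the six-membered aromatic ring of carbon only with a five-membered ring, and it weakens inhibition, giving an at least 2.2-fold higher number from compound 3 to compound 4 (0.34 log units; beyond the scatter) and an at least 8.1-fold higher number from compound 2 to compound 4 (0.91 log units; beyond the scatter). Ring size alone does not sort these compounds, however: compound 1 keeps a six-membered ring in its 4-chlorophenyl group and also gives a limit rather than a number, while compound 2 and compound 3 give measurable values with their six-membered rings. Compound 4 gives a limit of the assay and not a number, so both steps are bounds, and the step to compound 1 cannot be read: the limit of > 10000 nM in this assay, at which 2 of the 4 values shown sit.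

The compounds shown leave open whether the step comes from the five-membered ring itself or from the loss of ring substituents, a question that an unsubstituted phenyl group on the amide-type nitrogen would help to separate. They also leave open whether a methoxy group on the thiophene, a pyridine ring or a short alkyl chain at this position would give a measurable number in this assay.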